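The source may hold more compounds than are shown below. What is called first, only, known or untested is meant among the compounds shown, and "the series" means these compounds.

Compound 1 `NS(=O)(=O)c1ccc(N2N=C(c3cccc(O)c3)C[C@H]2c2ccccc2)cc1` — in a functional assay on the whole organism (strain Wistar albino) for inhibition, with Rattus norvegicus as the target, read by paw edema, with stated times of 30 min and 5 h, at a dose of 0.05 mmol/kg (on this read-out lower numbers stand for less inhibition and higher numbers for more inhibition at the one dose given (going by the name of the read-out)), compound 1 gives 77.7%
Compound 2 `NS(=O)(=O)c1ccc(N2N=C(c3cccc(O)c3)C[C@H]2c2ccc(Cl)cc2)cc1` — compound 2 gives 51.8%
Compound 3 `COc1ccc([C@@H]2CC(c3cccc(O)c3)=NN2c2ccc(S(N)(=O)=O)cc2)cc1` — compound 3 gives 62.9%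

Compound 3 stands second highest of the three numbers: its nearest neighbour is compound 2, which lies lower by a number 11.1 percentage points higher from compound 2 to compound 3 (beyond the scatter), and compound 1 stands higher by a number 14.8 percentage points lower from compound 1 to compound 3 (beyond the scatter), both gaps beyond the scatter. Compound 4 `Cc1ccc([C@@H]2CC(c3cccc(O)c3)=NN2c2ccc(S(N)(=O)=O)cc2)cc1` differs from compound 3 by methyl in place of methoxy on an aromatic carbon.

Within the data shown here, no measured step exchanges methyl for methoxy, so none bears on the change directly. What the steps do show is that every group placed on that ring has lowered the number relative to hydrogen: chloro by a number 25.9 percentage points lower from compound 1 to compound 2 (beyond the scatter) and methoxy by a number 14.8 percentage points lower from compound 1 to compound 3 (beyond the scatter), with the two substituted compounds differing by a number 11.1 percentage points higher from compound 2 to compound 3 (beyond the scatter). Methyl is therefore expected to leave compound 4 near compound 3, with a step of a number 4.9 percentage points lower from compound 3 to compound 4 (within the scatter), perhaps slightly downward but likely within the scatter. Compound 4 is thus estimated at 58%, in a range from 44% to 72%.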

Compound 4, a percentage reported as inhibition, in the whole organism at one dose (the size of the read-out at that dose, not a potency): 66%
Compound 4: middle estimate off by 8 percentage points, on the low side, within the range that was stated.
By their numbers in this assay, from the lowest: compound 2; then compounds 3 and 4 (each within the scatter of the next); then compound 1.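

In this assay, methyl in place of methoxy, on an aromatic carbon para to a large group, gives a number 3.1 percentage points higher from compound 3 to compound 4 (within the scatter), so removing the oxygen of the methoxy group produces no change that can be told apart from the scatter. Methyl also joins chloro and methoxy as a third group that stands clear of hydrogen at this place, with a number 11.7 percentage points lower from compound 1 to compound 4 (beyond the scatter), while it stands clear of chloro in the other direction, with a number 14.2 percentage points higher from compound 2 to compound 4 (beyond the scatter). Nothing measured here accounts for these steps.

As far as these compounds go, it remains open whether an amine, a carboxylic acid or a longer chain at this place would also fall short of hydrogen. The compounds shown also leave open whether these differences would hold at another dose or with methyl on another carbon of the ring.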